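Ethoxy replacing phenylsulfanyl in an acylguanidine sulfone series

The compounds below may be only part of what the source reports. "The series", "measured", "known", "first", "only" and "open" are said of these compounds alone.

Measured so far:
compound 1, `CCCc1cc(C)c(C(=O)N=C(N)N)cc1S(C)(=O)=O`, 5.7 nM in a functional assay for inhibition of sodium/hydrogen exchanger (Oryctolagus cuniculus); a lower number here means a stronger inhibitor, a higher number a weaker inhibitor
compound 2, `Cc1cc(Sc2ccccc2)c(S(C)(=O)=O)cc1C(=O)N=C(N)N`, 14 nM in this assay

Going by the values given here, compound 2 shows the highest number of the two measured values; its nearest neighbour is compound 1, and the single measured step gives a 2.5-fold higher number from compound 1 to compound 2 (0.39 log units; beyond the scatter). Compound 3, `CCOc1cc(C)c(C(=O)N=C(N)N)cc1S(C)(=O)=O`, has not yet been measured. It differs from compound 2 in one place: ethoxy in place of phenylsulfanyl on an aromatic carbon. Among the compounds with values here, no measured step carries this exact change. Within the data shown here, the one step that bears on the site is the move from propyl to phenylsulfanyl, which raised the number modestly from compound 1 to compound 2. Replacing phenylsulfanyl by ethoxy leaves a group that, like propyl, carries no ring, so compound 3 is expected to land between the two measured values or close to compound 1, meaning a 1.8-fold lower number from compound 2 to compound 3 (0.24 log units; within the scatter). For compound 3 the estimate in this assay is 8 nM, within 3.5 nM to 20 nM.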

Compound 3, half-maximal inhibitory concentration: 19 nM
Beside the measured number, compound 3's estimate is 2.4-fold (0.38 log units) below it; low and high end bracket the measured number.
By their numbers in this assay, from the lowest: compound 1; then compounds 2 and 3 (each within the scatter of the next).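

In this assay, ethoxy in place of phenylsulfanyl gives a 1.4-fold higher number from compound 2 to compound 3 (0.13 log units; within the scatter) and so stays within the scatter, which means that at this site, ortho to a methylsulfonyl group, going from 7 heavy atoms with a ring to 3 heavy atoms without one brings no readable change. Having no ring is also not enough to match compound 1, since ethoxy in place of propyl gives a 3.3-fold higher number from compound 1 to compound 3 (0.52 log units; beyond the scatter) and lies beyond the scatter, so two ring-free groups can be told apart at this site. The data offer no measured explanation for why propyl and ethoxy differ here.

As far as these compounds go, it remains open whether the low number of compound 1 is particular to propyl or is shared by other groups at this site. A longer chain such as butyl, a shorter ether such as methoxy or an amine such as dimethylamino could each land nearer compound 1 or nearer compounds 2 and 3.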